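The source may hold more compounds than are shown below. What is called first, only, known or untested is meant among the compounds shown, and "the series" means these compounds.

Measured so far in a functional assay on RKO cells (Homo sapiens) for cytotoxicity, read by resazurin assay, with a stated time of 72 h; on this read-out lower numbers stand for stronger inhibition and higher numbers for weaker inhibition:
Compound 1 `COc1ccc(Nc2nc(-n3ccnc3C)cs2)cc1` gives > 100000 nM, which is a limit of the assay and not a number.
Compound 2 `Cc1nccn1-c1csc(Nc2ccc(S(N)(=O)=O)cc2)n1` gives > 100000 nM, again a limit of the assay.
Going by the values given here, compound 3 `COc1ccc(Nc2nc(-n3c(C)nc4ccccc43)cs2)cc1` gives 52500 nM, the only number among the three.

Compound 2 differs from compound 1 by sulfamoyl in place of methoxy on an aromatic carbon. The step that the two limits leave unreadable from compound 1 to compound 2 cannot be read, because of the limit of > 100000 nM in this assay, at which 2 of the 3 values shown sit.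

Compound 4 `Cc1nc2ccccc2n1-c1csc(Nc2ccc(S(N)(=O)=O)cc2)n1` is the not yet measured partner of compound 3: it differs by sulfamoyl in place of methoxy on an aromatic carbon, the same change as that from compound 1 to compound 2, made at the same place. The difference between the two cores is not broken down here.

Among the compounds with values here, since the only measured example of this change is unreadable, the expectation for compound 4 rests on compound 3 alone, whose 52500 nM is weak. Compound 4 is expected to show a 1.1-fold higher number from compound 3 to compound 4 (0.06 log units; within the scatter) in this assay. Compound 4 is estimated at 60000 nM, between 15000 nM and 200000 nM.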

Compound 4, half-maximal inhibitory concentration: 95000 nM
The estimate for compound 4 lay 1.6-fold (0.20 log units) below the measured number, and the stated range covers the measured number.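

In this assay the swap of methoxy for sulfamoyl gives a 1.8-fold higher number from compound 3 to compound 4 (0.26 log units; within the scatter) and so, on this core, makes no difference that stands out from the usual scatter. The same swap on the core of compound 1 gives compound 2, but this step cannot be read, because both compounds give a limit and not a number: the limit of > 100000 nM in this assay, at which 2 of the 4 values shown sit. This leaves one readable example, so nothing shows whether the change behaves the same way on both cores.

The compounds shown leave open what other groups would do in this place on the aromatic ring, such as an amine or a carboxylic acid. From the compounds shown here alone, whether either would give a clear step on either core also remains open.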